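This account rests on a few compounds, and the source may have more. Where it says the series, first, only, none or still open, it means among the compounds named here.

Three selenium-bearing compounds share a closely related core, and a fourth waits for testing. Compound 1 `C[Se]c1nc(N)c2ccccc2n1` carries a methyl on its selenium. Compound 2 `Nc1nc([SeH])nc2ncccc12` has a selenium bearing hydrogen and an amino group on a core that differs from the core of compound 1 by one ring nitrogen. Compound 3 `[SeH]c1nc([SeH])c2cccnc2n1` carries two such selenium groups. In a functional assay on HT-29 cells (Homo sapiens) for cytotoxicity, read by MTT assay, with a stated time of 72 h (on this read-out lower numbers stand for higher toxicity in this test and higher numbers for lower toxicity in this test), compound 1 gives only a limit, > 100000 nM. In this assay compound 2 likewise gives only a limit, > 100000 nM. For compound 3 this assay reports "not determined" (no result reported), so no number exists. Compound 2 therefore stands where most of the shown results sit: the limit of > 100000 nM in this assay, at which 2 of the 3 values shown sit, with one further entry holding no number at all. Compound 4 `C[Se]c1nc(N)c2cccnc2n1` differs from compound 2 by methyl in place of hydrogen on a selenium. Among the compounds with values here, no step between measured compounds is available to guide the change, so the expected step from compound 2 to compound 4 is a number no higher from compound 2 to compound 4 (the limit leaves the size open), within the scatter. Compound 4 is estimated at 100000 nM, in a range from 50000 nM to 200000 nM, most likely again reported as a limit.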

Compound 4, concentration lethal to 50% of the cells: > 100000 nM
Compound 4 gave a limit, no number; the forecaster's own chance of this, stated with the estimate: 85%; the middle value lies on the limit itself.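

No step can be read from compound 2 to compound 4, since in this assay both results are limits and not numbers. The compounds shown leave open how toxic any of them is to these cells, and whether methyl in place of hydrogen on a selenium makes any difference.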